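Methyl in Place of Fluoro on a Benzylsulfonyl Ring

This account rests on a few compounds, and the source may have more. Where it says the series, first, only, none or still open, it means among the compounds named here.

Of the compounds shown here, three have been measured in a functional assay on DU-145 cells (Homo sapiens) for inhibition, read by trypan blue exclusion, with a stated time of 96 h; a lower number here means a stronger inhibitor of growth, a higher number a weaker inhibitor of growth. Compound 1 `O=C(/C(=C/c1ccc(Br)cc1)S(=O)(=O)Cc1ccc(I)cc1)c1ccc(I)cc1` gives 20000 nM in this assay. Compound 2 `CCOc1ccc(/C=C(\C(=O)c2ccc(Cl)cc2)S(=O)(=O)Cc2ccc(F)cc2)cc1OC` gives 50000 nM, and compound 3 `Cc1ccc(/C=C(\C(=O)c2ccc([N+](=O)[O-])cc2)S(=O)(=O)Cc2ccc(Cl)cc2)s1` gives 25000 nM. Compound 2 carries the highest number of the three. Its value and that of compound 3 lie within the scatter of each other, so nothing can be said about their order. Compound 1, however, sits beyond the scatter with a lower number, so compound 2 is the weaker growth inhibitor of that pair.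

Compound 4 `CCOc1ccc(/C=C(\C(=O)c2ccc(Cl)cc2)S(=O)(=O)Cc2ccc(C)cc2)cc1OC` has not yet been measured. It differs from compound 2 in a single place: methyl in place of fluoro on an aromatic carbon. Within the data shown here, no pair of measured compounds differs in only this way, so there is no measured step to lean on, and among compounds 1 to 3 the group on this ring changes together with changes elsewhere in the molecule.

With nothing in the data pointing either way, the step of a 1.3-fold lower number from compound 2 to compound 4 (0.10 log units; within the scatter) is expected to be small, with no change beyond the scatter in either direction. Compound 4 is therefore estimated at 40000 nM, with a range from 15000 nM to 100000 nM.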

Compound 4, concentration for 50% growth inhibition: 10000 nM
Beside the measured number, compound 4's estimate is 4.0-fold (0.60 log units) above it; the whole stated range lies above it.
By their numbers in this assay, from the lowest: compounds 4, 1, 3 and 2 (each within the scatter of the next, the first and the last beyond it).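

In this assay, going from 4-fluorobenzyl to 4-methylbenzyl gives a 5.0-fold lower number from compound 2 to compound 4 (0.70 log units; beyond the scatter), the only step shown that isolates this ring, as the group there changed together with other parts of the molecule among compounds 1 to 3. The position is therefore not silent: replacing one heavy atom with another, with no hydrogen-bond donors or acceptors and no net charge on either group, is enough to give a stronger inhibitor of growth by a margin beyond the scatter. No measurement shown bears on the reason for this step.

On these data alone, with only fluoro and methyl compared at this position on this core, it remains open whether the gain is specific to methyl or would also appear with a group such as ethyl, methoxy or an amine. As far as these compounds go, it is also open whether the same change would lower the number on the core of compound 1 or compound 3, where this ring carries iodo and chloro.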